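This account rests on a few compounds, and the source may have more. Where it says the series, first, only, none or still open, it means among the compounds named here.

For the measured compounds named here, compound 2 `C/C(=C\C(=O)Nc1ccccc1OCCCC(=O)O)c1ccc2c(ccn2C(C(C)C)C(C)C)c1` gives 14 nM in an assay on Prostate gland for inhibition of steroid 5-alpha-reductase (Rattus norvegicus) (a higher number here means a weaker inhibitor, a lower number a stronger inhibitor), the lowest of the two numbers so far. Going by the values given here, compound 1 `CCCCCCn1ccc2cc(/C(C)=C/C(=O)Nc3ccccc3OCCCC(=O)O)ccc21` gives 77 nM in this assay; the one step at the aromatic nitrogen, a 5.5-fold lower number from compound 1 to compound 2 (0.74 log units; beyond the scatter), shows this position can shift the number well beyond the scatter. Compound 3 `C/C(=C\C(=O)Nc1ccccc1OCCCC(=O)O)c1ccc2c(ccn2Cc2cccc(C)c2)c1` carries 3-methylbenzyl in place of 1-isopropyl-2-methylpropyl on an aromatic nitrogen. Among the compounds with values here, no measured step covers an aromatic group at this nitrogen, so that single step is the only guide. The change from compound 2 to compound 3 is expected to be a 1.8-fold higher number from compound 2 to compound 3 (0.25 log units; within the scatter), likely within the scatter. Compound 3 is estimated at 25 nM, in the range 8 nM to 80 nM.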

Compound 3, half-maximal inhibitory concentration: 250 nM
Compound 3: middle estimate off by 10-fold (1.00 log units), on the low side, and the stated range ends below it.
By their numbers in this assay, from the lowest: compound 2; then compound 1; then compound 3.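

In this assay, for the compounds shown here, the step to 3-methylbenzyl on the aromatic nitrogen is large (an 18-fold higher number from compound 2 to compound 3 (1.25 log units; beyond the scatter)), so this position spans more than the single earlier step showed. The ring-bearing group also falls behind the straight chain (a 3.2-fold higher number from compound 1 to compound 3 (0.51 log units; beyond the scatter)), which makes compound 3 the weakest inhibitor of the three. Nothing available explains this loss. Open, on these data alone, is whether the loss follows the benzyl ring itself or its methyl group, which an unsubstituted benzyl group would separate. Also open, as far as these compounds go, is whether a smaller branched group such as isopropyl keeps the low number of compound 2.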